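Isopropoxy removal from compound 1

The source may hold more compounds than are shown below. What is called first, only, known or untested is meant among the compounds shown, and "the series" means these compounds.

Compound 1 `COc1ccc(C2=C(c3cc(OC)c(OC)c(OC)c3)C(=O)C(OC(C)=O)C2)cc1OC(C)C` gives > 100 ug/mL in an ADME assay on MIA PaCa-2 cells (Homo sapiens) for cytotoxicity, read by MTT assay, with a stated time of 72 h (a higher number here means a weaker inhibitor, a lower number a stronger inhibitor), as a limit of the assay, not a number. Compound 2 `COc1ccc(C2=C(c3cc(OC)c(OC)c(OC)c3)C(=O)CC2C)cc1C(=O)O` gives > 100 ug/mL in this assay as a limit too. Among the compounds with values here, the series therefore holds only the limit of > 100 ug/mL in this assay, at which 2 of the 2 values shown sit, and no measured step between compounds.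

Compound 3 `COc1ccc(C2=C(c3cc(OC)c(OC)c(OC)c3)C(=O)C(OC(C)=O)C2)cc1` keeps the core of compound 1 and carries hydrogen in place of isopropoxy on an aromatic carbon, ortho to a methoxy group and meta to a large group (hydrogen in place of isopropoxy on an aromatic carbon). Within the data shown here, no measured pair shows what a change of this kind does in this assay and the expectation stays loose. It rests on compound 1 alone, whose > 100 ug/mL is a limit. A modest expected step of an at least 1.2-fold lower number from compound 1 to compound 3 (0.09 log units; that floor lies within the scatter) points toward a stronger inhibitor, though another reading that gives only a limit is about as likely. For compound 3 the estimated value is 80 ug/mL with 20 ug/mL to 200 ug/mL as the expected range.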

Compound 3, half-maximal inhibitory concentration: < 1 ug/mL
Compound 3 gave a limit, no number; the forecaster's own chance of this, stated with the estimate: 55%; at least 80-fold (1.90 log units) between middle value and limit.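

In this assay, within the data shown here, hydrogen in place of isopropoxy on an aromatic carbon, ortho to a methoxy group and meta to a large group, gives the first measured step: an at least 100-fold lower number from compound 1 to compound 3 (2.00 log units; beyond the scatter). Both ends of this step are limits, so it sets a floor on the change and does not give its size, but even that floor shows that this single position can move the reading across the whole span of values shown, with the rest of the core of compound 1 left unchanged. Compound 3 is also the only compound shown to sit at the low end of that span: the limit of < 1 ug/mL in this assay, at which 1 of the 3 values shown sits.

The compounds shown do not tell whether the step depends on removing bulk at this aromatic carbon or on removing the ether oxygen, since only the pair of isopropoxy and hydrogen can be compared here. A hydroxyl, an ethoxy or an amine on the same carbon would place readings along this step, and a numerical value for compound 3 would be needed to give the step a size.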